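Sulfonamide series: relocating the carboxyl on the aryl sulfonyl

The source may report more compounds than this note shows. Statements on the series, on what has been measured and on what is new or still open speak of the compounds shown alone.

Compound 3 `O=C(O)c1cccc(S(=O)(=O)N2CCC(NS(=O)(=O)c3cc(S(=O)(=O)c4ccccc4)ccc3C(F)(F)F)CC2)c1` gives 190 nM in an assay on U2OS cells for inhibition of secreted frizzled-related protein 1 (Homo sapiens), read by a luciferase reporter, with a stated time of 18 h (a higher number here means that more compound is needed for the effect, a lower number that less compound is needed), the second highest of the three numbers. Compound 1 `O=C(c1ccccc1)N1CCC(NS(=O)(=O)c2cc(S(=O)(=O)c3ccccc3)ccc2C(F)(F)F)CC1` is nearest at 250 nM; the step of a 1.3-fold lower number from compound 1 to compound 3 (0.12 log units; within the scatter) lies within the scatter. Compound 2 `CN(C)c1ccc(C(=O)N2CCC(NS(=O)(=O)c3cc(S(=O)(=O)c4ccccc4)ccc3C(F)(F)F)CC2)cn1` is furthest at 70 nM; the step of a 2.7-fold higher number from compound 2 to compound 3 (0.43 log units; beyond the scatter) lies beyond it. Compound 4 `O=C(O)c1ccc(S(=O)(=O)N2CCC(NS(=O)(=O)c3cc(S(=O)(=O)c4ccccc4)ccc3C(F)(F)F)CC2)cc1` differs from compound 3 only by 4-carboxyphenyl in place of 3-carboxyphenyl on a sulfonyl sulfur. For the measured compounds named here, no measured step changes where the carboxyl sits, so none bears on it directly; the one step on the same ring nitrogen, a 1.3-fold lower number from compound 1 to compound 3 (0.12 log units; within the scatter), was within the scatter, and a 3.6-fold lower number from compound 1 to compound 2 (0.55 log units; beyond the scatter) was modest. For compound 4 no step beyond the scatter is expected, so no change at the digits printed from compound 3 to compound 4 (within the scatter) is the estimate. Compound 4 is therefore expected at 190 nM, between 70 nM and 520 nM.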

Compound 4, half-maximal effective concentration: 110 nM
Compound 4: the middle estimate sits 1.7-fold (0.24 log units) above what was measured; the measured number falls inside the stated range.
By their numbers in this assay, from the lowest: compounds 2, 4, 3 and 1 (each within the scatter of the next, the first and the last beyond it).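

In this assay, 4-carboxyphenyl in place of 3-carboxyphenyl on a sulfonyl sulfur gives a 1.7-fold lower number from compound 3 to compound 4 (0.24 log units; within the scatter) and so does not separate the two sites of the carboxyl. Against benzoyl, (4-carboxyphenyl)sulfonyl gives a 2.3-fold lower number from compound 1 to compound 4 (0.36 log units; beyond the scatter) and stands clear of the scatter, a separation that the (3-carboxyphenyl)sulfonyl group did not reach, while against (6-(dimethylamino)pyridin-3-yl)carbonyl it gives a 1.6-fold higher number from compound 2 to compound 4 (0.20 log units; within the scatter) and stays inside the scatter. Open, going by these compounds, is whether a primary amide or a methyl ester in place of the carboxylic acid on the (4-carboxyphenyl)sulfonyl group holds the number. Nothing at hand accounts for these steps.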